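The compounds below may be only part of what the source reports. "The series", "measured", "known", "first", "only" and "open" are said of these compounds alone.

Working notes on the series. Compound 1 `CCCCCNc1oc2c(C)ncc(CO)c2c1Nc1ccccn1` gives 5810 nM in a functional assay on HEK293 cells for agonist activity at Toll-like receptor 8 (Homo sapiens), read by reporter gene assay; on this read-out higher numbers stand for an effect only at larger amounts of compound and lower numbers for an effect already at smaller amounts. Compound 3 `CCCCCNc1oc2c(C)ncc(CO)c2c1Nc1cccc(F)c1` gives 370 nM. Compound 2 `Cc1ncc(CO)c2c(Nc3ccccc3)c(NCc3ccccc3)oc12` gives 1680 nM, which places it second highest of the three numbers: compound 1 sits above it by a gap beyond the scatter, and compound 3 sits below it by a gap that is also beyond the scatter. Compound 4 `Cc1ncc(CO)c2c(Nc3ccccn3)c(NCc3ccccc3)oc12` has not yet been measured. It differs from compound 2 by pyridin-2-yl in place of phenyl on a nitrogen on an aromatic ring. Going by the values given here, one measured step bears on this change: a 16-fold lower number from compound 1 to compound 3 (1.20 log units; beyond the scatter), in which pyridin-2-yl left and the number dropped sharply. The present change runs the other way, bringing pyridin-2-yl in, although the partner here is plain phenyl rather than 3-fluorophenyl. Among the compounds with values here, no measured pair compares pyridin-2-yl with plain phenyl directly. The expected step is therefore a 6.0-fold higher number from compound 2 to compound 4 (0.77 log units; beyond the scatter), an upward move, because of the size of a 16-fold lower number from compound 1 to compound 3 (1.20 log units; beyond the scatter). The estimate for compound 4 in this assay is 10000 nM, with a range from 3000 nM to 40000 nM.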

Compound 4, half-maximal effective concentration: 4910 nM
Estimate against measurement, compound 4: 2.0-fold (0.31 log units) above, within the range that was stated.
By their numbers in this assay, from the lowest: compound 3; then compound 2; then compounds 4 and 1 (each within the scatter of the next).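

In this assay, the exchange of phenyl for pyridin-2-yl on a nitrogen on an aromatic ring now has a direct measured pair, a 2.9-fold higher number from compound 2 to compound 4 (0.47 log units; beyond the scatter), so the upward direction also holds against plain phenyl, though this modest step differs in both partner group and chain from the large step of a 16-fold lower number from compound 1 to compound 3 (1.20 log units; beyond the scatter). With pyridin-2-yl held on that nitrogen, the other exchange in the series gives a 1.2-fold lower number from compound 1 to compound 4 (0.07 log units; within the scatter), so phenyl and butyl on a saturated chain carbon bound to a nitrogen on an aromatic ring cannot be told apart in this pair. No measurement shown here accounts for either result.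

The compounds shown leave open whether phenyl and butyl on that chain carbon also read alike when phenyl or 3-fluorophenyl replaces pyridin-2-yl on the nitrogen, and how plain phenyl compares directly with 3-fluorophenyl. Also open, going by these compounds, is how pyridin-3-yl, or a phenyl ring carrying an amine or a carboxylic acid, would read on the same nitrogen.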